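Ester and Ether Changes on an Inactive Core

The compounds below may be only part of what the source reports. "The series", "measured", "known", "first", "only" and "open" are said of these compounds alone.

Compound 1 `CCOC(=O)c1ccc(-c2ccc(N(C)C)nn2)cc1` was tested in a functional assay on HCT-116 cells (Homo sapiens) for antiproliferative activity, with a stated time of 48 h; on this read-out higher numbers stand for weaker inhibition and lower numbers for stronger inhibition. In this assay compound 1 reaches only the limit of > 25000 nM. Compound 2 `COC(=O)c1ccc(-c2ccc(N(C)C)nn2)cc1` also gives only the limit of > 25000 nM. Compound 3 `CCOC(=O)c1ccc(-c2ccc(OCC)nn2)cc1` likewise stops at the limit of > 25000 nM. The change methyl in place of hydrogen on a saturated chain carbon bound to an oxygen next to a carbonyl group gives a step that the two limits leave unreadable from compound 2 to compound 1, and the change from compound 1 to compound 3, ethoxy in place of dimethylamino on an aromatic carbon, gives a step that the two limits leave unreadable from compound 1 to compound 3; both sizes stay hidden because of the limit of > 25000 nM in this assay, at which 3 of the 3 values shown sit. The difference between the cores of compound 2 and compound 3 is not broken down here. Compound 4 `CCOC(=O)c1ccc(-c2ccc(OC(C)C)nn2)cc1` is not yet measured; it differs from compound 3 by methyl in place of hydrogen on a saturated chain carbon bound to an oxygen on an aromatic ring and a saturated chain carbon, the same kind of change as before, though here the carbon is bound to an oxygen on an aromatic ring and a saturated chain carbon rather than to an oxygen next to a carbonyl group. Resting on (the limit of > 25000 nM in this assay, at which 3 of the 3 values shown sit), compound 4 is expected to give 30000 nM, an expected step that the limit leaves unreadable from compound 3 to compound 4, most likely again only a limit.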

Compound 4, half-maximal inhibitory concentration: > 25000 nM
Compound 4 ended at the assay's limit; the forecaster's own chance of this, stated with the estimate: 85%; the middle value is on the limit's open side.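

The steps from compound 3 and from compound 1 to compound 4 cannot be read, because each compound gives only a limit, not a number: the limit of > 25000 nM in this assay, at which 4 of the 4 values shown sit.

The compounds shown leave open how weak each one truly is and whether any change on this core gives a measurable effect.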